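The source may report more compounds than this note shows. Statements on the series, on what has been measured and on what is new or still open speak of the compounds shown alone.

Measured in a physicochemical assay for lipophilicity; a higher number here means a more lipophilic compound, a lower number a more polar compound:
- compound 1 `Cc1cccc(-c2cc(Nc3ccc4nc(-c5ccc(F)cc5)cc(N)c4c3)nc(N)n2)c1`: 3.18
- compound 2 `Nc1nc(Nc2ccc3nc(-c4ccc(F)cc4)cc(N)c3c2)cc(-c2cccc(Cl)c2)n1`: 3.06

Compound 1 and compound 2 lie within the scatter of each other, so these two numbers set neither compound apart. The next step leads to compound 3 `Nc1nc(Nc2ccc3nc(-c4ccc(F)cc4)cc(N)c3c2)cc(-c2ccc(F)cc2)n1` and puts 4-fluorophenyl in place of 3-methylphenyl on an aromatic carbon. Among the measured compounds shown here, only one measured step bears on this change. It is a number 0.12 log units lower from compound 1 to compound 2 (within the scatter), a small step with chloro in place of methyl. For the measured compounds named here, no measured compound carries 4-fluorophenyl at this carbon, so this step is only a loose guide. A slightly lower number is expected, but no step beyond the scatter. The estimated step is a number 0.18 log units lower from compound 1 to compound 3 (within the scatter) in this assay, with the direction itself uncertain. For compound 3 the expected value is 3, with an estimated range from 2.65 to 3.35 for this measurement.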

Compound 3, distribution coefficient: 3.06
Beside the measured number, compound 3's estimate is 0.06 log units below it; the measured number falls inside the stated range.
By their numbers in this assay, from the lowest: compounds 2, 3 and 1 (each within the scatter of the next).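

In this assay the exchange of 3-methylphenyl for 4-fluorophenyl on this aromatic carbon gives a number 0.12 log units lower from compound 1 to compound 3 (within the scatter) and the exchange of 3-chlorophenyl for 4-fluorophenyl gives no change at the digits printed from compound 2 to compound 3 (within the scatter) in the same read-out. The earlier pair covered only chloro in place of methyl, whereas these steps add a fluorine-bearing phenyl group, and the three phenyl groups at this carbon are still not told apart by these numbers. No supporting data on the origin of these small steps are available. The compounds shown leave open whether any group at this carbon can move the number beyond the scatter. An aminomethyl group, a carboxylic acid or a morpholine in place of the phenyl ring would test this, since every group shown so far is a substituted phenyl ring.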